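The source may report more compounds than this note shows. Statements on the series, on what has been measured and on what is new or still open speak of the compounds shown alone.

Measured so far:
compound 1, `COc1ccc(CCOC(=O)N(c2ccccc2)C2CN3CCC2CC3)cc1OC`, gives 3490 nM in an assay on CHO cells for displacement of a labelled ligand from muscarinic acetylcholine receptor M5 (Homo sapiens), read by scintillation counting, with a stated time of 2 h; on this read-out lower numbers stand for stronger inhibition and higher numbers for weaker inhibition;
compound 2, `O=C(OCCCc1ccccc1)N(c1ccccc1)C1CN2CCC1CC2`, gives 260 nM in this assay.

Of these two numbers, compound 2 has the lower one, and the gap to compound 1 is well beyond the scatter. Going by the values given here, the one measured step, a 13-fold lower number from compound 1 to compound 2 (1.13 log units; beyond the scatter), replaced a ring that carried two methoxy groups with a bare phenyl ring and moved that ring one bond further out along the chain.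

Compound 3, `O=C(OCCCc1ccc(Cl)c(Cl)c1)N(c1ccccc1)C1CN2CCC1CC2`, has not yet been measured. It differs from compound 2 by 3,4-dichlorophenyl in place of phenyl on a saturated chain carbon, three bonds along the chain from an oxygen next to a carbonyl group. So the ring at the end of the chain again carries two substituents, now chlorines instead of methoxy groups, at the same two positions that in compound 1 went with the much higher number. Among the compounds with values here, that is the only measured step that touches this part of the molecule, and it does not test chlorine itself, so the expectation is uncertain. Taking the step from compound 1 to compound 2 as the nearest guide, the number for compound 3 is expected to rise somewhat, by a 2.3-fold higher number from compound 2 to compound 3 (0.36 log units; beyond the scatter). The estimate for compound 3 in this assay is 600 nM, within a range from 150 nM to 2500 nM.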

Compound 3, inhibition constant: 130 nM
Compound 3: middle estimate off by 4.6-fold (0.66 log units), on the high side, outside the stated range (below it).
By their numbers in this assay, from the lowest: compounds 3 and 2 (each within the scatter of the next); then compound 1.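

Compound 3 places two chlorines on the ring at the end of the chain of compound 2. In this comparison (this assay), the step (a 2.0-fold lower number from compound 2 to compound 3 (0.30 log units; within the scatter)) lies within the scatter, so this position accepts 3,4-dichlorophenyl in place of phenyl without a measurable change. Two substituents on this ring therefore do not by themselves go with a high number, as the large step beyond the scatter (a 27-fold lower number from compound 1 to compound 3 (1.43 log units; beyond the scatter)) shows, although that step changes both the substituents and the chain length. No measurement shown here explains why these numbers fall as they do.

The compounds shown do not separate the part played by the methoxy groups from the part played by the chain length, since the two change together between the dimethoxy and dichloro compounds. From the compounds shown here alone, it also remains open how a single chlorine, a trifluoromethyl group, an amine or a carboxylic acid on this ring would read, and whether a longer chain would keep a number like that of compound 2.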